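The source may hold more compounds than are shown below. What is called first, only, known or untested is meant among the compounds shown, and "the series" means these compounds.

Measured in an ADME assay on CHO cells (Cricetulus griseus) for cytotoxicity; on this read-out higher numbers stand for weaker inhibition and lower numbers for stronger inhibition:
- compound 1 `Cc1cc(C(=O)Nc2cc(Nc3cnccn3)nc(-c3ccnc(N4CCNCC4)c3)c2)n(C)n1`: > 20000 nM
- compound 2 `FC(F)(F)c1ccnc(Nc2cccc(-c3ccnc(N4CCNCC4)c3)n2)c1`: 1000 nM

Compound 1 stands on (the limit of > 20000 nM in this assay, at which 1 of the 2 values shown sits). This is a limit and not a number, so the starting point of the step has no exact position.

Compound 3 `O=C(Nc1cc(Nc2cnccn2)nc(-c2ccnc(N3CCNCC3)c2)c1)C1CCNCC1` keeps the core of compound 1 and carries piperidin-4-yl in place of 1,3-dimethyl-1H-pyrazol-5-yl on a carbonyl carbon. Within the data shown here, no measured step covers this change. Among the measured compounds shown here, compound 2 gives 1000 nM, the only actual number so far, and this is the sole guide to where a value can lie.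

The expected step is an at least 2.5-fold lower number from compound 1 to compound 3 (0.39 log units; beyond the scatter), towards stronger inhibition in this assay, and its estimated size is rough. For compound 3 the estimate is 8000 nM, with an expected range from 2500 nM to 20000 nM.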

Compound 3, half-maximal inhibitory concentration: > 20000 nM
Compound 3: no number, only a limit (the forecaster's own chance of this, stated with the estimate: 35%); middle value at least 2.5-fold (0.39 log units) away from the limit.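

In this assay compound 1 and compound 3 both give a limit and not a number, so no step can be read between them: the limit of > 20000 nM in this assay, at which 2 of the 3 values shown sit. The compounds shown leave open whether piperidin-4-yl in place of 1,3-dimethyl-1H-pyrazol-5-yl on a carbonyl carbon shifts this read-out at all.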